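A few compounds are considered here, and "the series" means these few. Any claim that something is new, unique, unknown or untested is made for them only; others in the source may bear on it.

Compound 1 `CCn1nc(-c2nccs2)c2ccccc2c1=O`: 3160 nM
Compound 2 `CCn1nc(-c2cncs2)c2ccccc2c1=O`: 562 nM

In a functional assay (trachea) with Cavia porcellus as the target (a higher number here means a weaker inhibitor, a lower number a stronger inhibitor), compound 2 holds the lower of the two numbers, at 562 nM. For the measured compounds named here, the only measured step, a 5.6-fold lower number from compound 1 to compound 2 (0.75 log units; beyond the scatter), is a modest one beyond the scatter, and it comes from 1,3-thiazol-5-yl standing in place of 1,3-thiazol-2-yl on an aromatic carbon.

Compound 3 `CCn1nc(-c2cnccn2)c2ccccc2c1=O` carries pyrazin-2-yl in place of 1,3-thiazol-5-yl on an aromatic carbon, next to the ring nitrogen: pyrazin-2-yl in place of 1,3-thiazol-5-yl on an aromatic carbon. Going by the values given here, no measured step covers this exchange, so the step to compound 2 at a 5.6-fold lower number from compound 1 to compound 2 (0.75 log units; beyond the scatter) serves only as a rough guide to size. A step of similar or smaller size is expected in this assay, more likely towards a higher number, though the direction remains uncertain. The estimate amounts to an expected 2.5-fold higher number from compound 2 to compound 3 (0.40 log units; beyond the scatter). For compound 3 the expected value is 1400 nM, with an estimated range of 300 nM to 6000 nM.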

Compound 3, half-maximal inhibitory concentration: 11000 nM
Estimate against measurement, compound 3: 7.9-fold (0.90 log units) below; the measured number lies above the stated range.
By their numbers in this assay, from the lowest: compound 2; then compound 1; then compound 3.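

In this assay, pyrazin-2-yl on this aromatic carbon, next to the ring nitrogen, gives a 20-fold higher number from compound 2 to compound 3 (1.29 log units; beyond the scatter) and the largest step among the three compounds, while the comparison with the other thiazole gives a 3.5-fold higher number from compound 1 to compound 3 (0.54 log units; beyond the scatter) and is also beyond the scatter. Compound 3 therefore holds the highest number of the three, so this position responds to more than the attachment of a thiazole: the six-membered ring falls behind both five-membered rings, although the groups exchanged have the same counts of hetero atoms, donors and acceptors. Nothing available here gives a reason for this loss.

As far as these compounds go, whether ring size or the placement of the ring nitrogens sets the result remains open. So does how a phenyl or pyridin-2-yl group, or an amine, would behave on this carbon.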